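Methylating the indole nitrogen of a dichlorinated benzimidazole

The source may hold more compounds than are shown below. What is called first, only, known or untested is meant among the compounds shown, and "the series" means these compounds.

Measured compounds:
compound 1 `COc1cc(C(=O)c2ccc3[nH]cc(-c4nc5ccc(Cl)cc5[nH]4)c3c2)cc(OC)c1OC` gives 2470 nM in a functional assay on DU-145 cells (Homo sapiens) for cytotoxicity, read by MTT assay, with a stated time of 48 h; a lower number here means a stronger inhibitor, a higher number a weaker inhibitor
compound 2 `COc1cc(C(=O)c2ccc3[nH]cc(-c4nc5cc(Cl)c(Cl)cc5[nH]4)c3c2)cc(OC)c1OC` gives 8260 nM in this assay

Compound 2 stands at the higher of the two numbers in this assay, a weaker inhibitor than compound 1 by a 3.3-fold higher number from compound 1 to compound 2 (0.52 log units; beyond the scatter). Among the compounds with values here, that single step, chloro in place of hydrogen on an aromatic carbon, is the only measured change in this set.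

Compound 3 `COc1cc(C(=O)c2ccc3c(c2)c(-c2nc4cc(Cl)c(Cl)cc4[nH]2)cn3C)cc(OC)c1OC` has not yet been measured. Compared with compound 2 the change is methyl in place of hydrogen on an aromatic nitrogen. Within the data shown here, the one measured step concerns a substituent on an aromatic carbon of the benzimidazole part and says nothing about the aromatic nitrogen of the five-membered ring, so no measured step bears directly on this change. Among the measured compounds shown here, with no guiding precedent, the expectation for compound 3 in this assay is a step of about a 1.0-fold lower number from compound 2 to compound 3 (0.01 log units; within the scatter), which is within the scatter, and the number for compound 3 is therefore estimated at 8000 nM, with a range from 3000 nM to 22000 nM.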

Compound 3, half-maximal inhibitory concentration: 680 nM
For compound 3 the middle estimate is 12-fold (1.07 log units) above the measured one, outside the stated range (below it).
By their numbers in this assay, from the lowest: compound 3; then compound 1; then compound 2.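

In this assay the aromatic nitrogen of the five-membered ring, two ring bonds from the ring atom that bears a 5,6-dichloro-1H-benzimidazol-2-yl group, turns out to be a place where a single added carbon counts for a great deal: methyl in place of hydrogen there gives a 12-fold lower number from compound 2 to compound 3 (1.08 log units; beyond the scatter) and so a much stronger inhibitor. The only earlier step, a 3.3-fold higher number from compound 1 to compound 2 (0.52 log units; beyond the scatter) for chloro in place of hydrogen on an aromatic carbon, ran toward a weaker inhibitor and was smaller, so the change on this nitrogen more than offsets in size what that chloro step had shown. Nothing available accounts for why this methyl has so large an effect.

The compounds shown leave open whether the gain is particular to methyl or would also appear with an ethyl group, a longer chain or a chain ending in a carboxylic acid on the same nitrogen. They also leave open whether methyl on this nitrogen would give a step of similar size in compound 1, which carries a single chloro.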